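Shortening and Stiffening the Acid Chain of Compound 2

The source may report more compounds than this note shows. Statements on the series, on what has been measured and on what is new or still open speak of the compounds shown alone.

Compound 2 `O=C(O)CCCc1ccccc1-c1cccc(-c2ccccc2OCc2ccccc2)c1` carries a 3-carboxypropyl chain on its core. Going by the values given here, in an assay on HEK293 cells for binding affinity to prostaglandin E2 receptor EP3 subtype (Homo sapiens) (a higher number here means a weaker inhibitor, a lower number a stronger inhibitor), compound 2 gives 590 nM, the highest of the three numbers measured so far. Its nearest neighbour is compound 1 `O=C(O)CCc1ccccc1-c1cccc(-c2ccccc2OCc2ccccc2)c1`, which in this assay gives 55 nM; the furthest is compound 3 `O=C(O)CCc1ccccc1-c1cc(-c2ccccc2OCc2ccccc2)cs1`, which gives 27 nM in this assay.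

Compound 4 `O=C(O)/C=C/c1ccccc1-c1cccc(-c2ccccc2OCc2ccccc2)c1` differs from compound 2 in a single place: 2-carboxyethenyl in place of 3-carboxypropyl on an aromatic carbon. The entering chain is shorter than the leaving one and holds a double bond outside the aromatic rings, so it matches the chain length of compound 1 while no longer being fully saturated.

Among the compounds with values here, only one measured step bears directly on this change. The step of an 11-fold higher number from compound 1 to compound 2 (1.03 log units; beyond the scatter) shows that adding a chain carbon weakened binding markedly, and compound 4 undoes that addition. Because compound 1, with the shorter saturated chain, gives 55 nM, compound 4 is expected to land close to that value, a fall of about a 7.4-fold lower number from compound 2 to compound 4 (0.87 log units; beyond the scatter). Within the data shown here, the double bond has no measured precedent here, which widens the uncertainty. The estimate for compound 4 in this assay is 80 nM, within a range from 25 nM to 300 nM.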

Compound 4, inhibition constant: 84 nM
Estimate against measurement, compound 4: 1.1-fold (0.02 log units) below; the range from low to high includes it.
By their numbers in this assay, from the lowest: compound 3; then compounds 1 and 4 (each within the scatter of the next); then compound 2.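

In this assay, putting 2-carboxyethenyl in place of 3-carboxypropyl on this aromatic carbon gives a 7.0-fold lower number from compound 2 to compound 4 (0.85 log units; beyond the scatter), so the longer chain is not needed for the lower number, and the chain can hold a double bond outside the aromatic rings and still reach it. The saturated 2-carboxyethyl chain and the unsaturated 2-carboxyethenyl chain compare as a 1.5-fold higher number from compound 1 to compound 4 (0.18 log units; within the scatter), which means that at this position the two chains cannot be told apart in this measurement, while the step from the longest chain stands clear of the scatter. Nothing in the data offers an explanation for either step.

The compounds shown leave open whether a chain with a double bond behaves the same way on the core of compound 3, which gives 27 nM, since only the core of compound 1 carries it here. They also leave open how a still shorter carboxymethyl chain, or an amide in place of the carboxylic acid, would fare at this same aromatic carbon.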